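Swapping Ethoxy for Cyclopropyl on a Carbonyl Carbon

The source may hold more compounds than are shown below. What is called first, only, known or untested is meant among the compounds shown, and "the series" means these compounds.

Of the compounds shown here, three built on one shared core have been measured in a physicochemical assay for lipophilicity, read by HPLC, with a stated time of 90 min, tested at 100 uM; on this read-out higher numbers stand for higher lipophilicity and lower numbers for lower lipophilicity. Compound 1 `CC(C)C(=O)N1CCC(NC(=O)Nc2ccc(OC(F)(F)F)c(F)c2)CC1` gives 4.73, compound 2 `CCOC(=O)N1CCC(NC(=O)Nc2ccc(C(F)(F)F)c(F)c2)CC1` gives 5.46, and compound 3 `CCOC(=O)N1CCC(NC(=O)Nc2ccc(OC(F)(F)F)c(F)c2)CC1` gives 5.94, the highest of the three. Going by the values given here, only one change separates compound 2 from compound 3, and a number 0.48 log units higher from compound 2 to compound 3 (beyond the scatter).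

Compound 4 `O=C(Nc1ccc(OC(F)(F)F)c(F)c1)NC1CCN(C(=O)C2CC2)CC1` has not yet been measured. It differs from compound 3 in one place: cyclopropyl in place of ethoxy on a carbonyl carbon. The change on the aromatic carbon does not bear on this; the change on the carbonyl carbon does. Compound 1 carries isopropyl where compound 3 carries ethoxy, and a number 1.21 log units higher from compound 1 to compound 3 (beyond the scatter), a large step. Cyclopropyl, like isopropyl, is made of carbon only, so moving from ethoxy to such a group is expected to undo much of that step. Compound 4 is therefore expected to show a number 1.34 log units lower from compound 3 to compound 4 (beyond the scatter) in this assay. The estimate for compound 4 is 4.6, within 4.1 to 5.1.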

Compound 4, partition coefficient: 4.19
Compound 4: middle estimate off by 0.41 log units, on the high side; the measured number falls inside the stated range.
By their numbers in this assay, from the lowest: compound 4; then compound 1; then compound 2; then compound 3.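

Going by these compounds alone, at this carbonyl carbon, two groups made of carbon only do not read alike in this assay: cyclopropyl in place of isopropyl gives a number 0.54 log units lower from compound 1 to compound 4 (beyond the scatter), a difference the earlier compounds could not show. The swap of ethoxy for cyclopropyl gives a number 1.75 log units lower from compound 3 to compound 4 (beyond the scatter), so ethoxy now stands apart from a second carbon-only group at this position, not just from isopropyl. Nothing measured here accounts for either step.

On these data alone, whether a cyclobutyl or a methoxy group on the same carbonyl carbon would read closer to cyclopropyl, isopropyl or ethoxy remains open. As far as these compounds go, it is also open whether the swap of ethoxy for cyclopropyl would give a step of the same size with trifluoromethyl in place of trifluoromethoxy on the aromatic carbon.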